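This account rests on a few compounds, and the source may have more. Where it says the series, first, only, none or still open, it means among the compounds named here.

In a functional assay on LoVo cells (Homo sapiens) for inhibition, read by MTT assay, with a stated time of 24 h (a higher number here means a weaker inhibitor, a lower number a stronger inhibitor), compound 1 `CC1(C)[C@H]2CC[C@]1(C)N(Cc1cn(-c3cccc(C#N)c3)nn1)C(=O)C2` gives 320 nM, and compound 2 `CC1(C)[C@H]2CC[C@]1(C)N(Cc1cn(-c3cccc(Cl)c3)nn1)C(=O)C2` gives 70 nM, the lower of the two numbers and so the stronger inhibitor of the pair. Compound 3 `COc1ccccc1-n1cc(CN2C(=O)C[C@@H]3CC[C@@]2(C)C3(C)C)nn1` keeps the shared core but has 2-methoxyphenyl in place of 3-chlorophenyl on an aromatic nitrogen. Within the data shown here, only one measured step bears on this change, a 4.6-fold lower number from compound 1 to compound 2 (0.66 log units; beyond the scatter), a modest step made by chloro in place of cyano on an aromatic carbon. Among the measured compounds shown here, it shows that this aromatic ring can alter the number, but no measured compound carries a methoxy group, so the evidence is indirect. Since compound 1, the only other variant, gives 320 nM, a modest step toward a higher number is expected, similar in size to the measured one. The expected move is a 2.6-fold higher number from compound 2 to compound 3 (0.41 log units; beyond the scatter). For compound 3 the estimated value is 180 nM, with an expected range of 45 nM to 700 nM.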

Compound 3, half-maximal inhibitory concentration: 70 nM
Estimate against measurement, compound 3: 2.6-fold (0.41 log units) above; the range from low to high includes it.
By their numbers in this assay, from the lowest: compounds 2 and 3 (each within the scatter of the next); then compound 1.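

Among these compounds, replacing 3-chlorophenyl with 2-methoxyphenyl on the aromatic nitrogen gives no change at the digits printed from compound 2 to compound 3 (within the scatter) in this assay, so a ring bearing a methoxy group, absent from the earlier compounds, matches the number given by the chlorine-bearing ring. Against 3-cyanophenyl, the same change gives a 4.6-fold lower number from compound 1 to compound 3 (0.66 log units; beyond the scatter), leaving the higher number with 3-cyanophenyl alone among these three compounds. Nothing measured here accounts for this pattern in terms of the groups' properties.

The two groups differ both in their substituent and in its place on the phenyl ring, so compounds 2 and 3 cannot show which of these matters, if either. On these data alone, how a phenyl ring carrying an amine or a carboxylic acid would behave at this position also remains open.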